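A few compounds are considered here, and "the series" means these few. Any claim that something is new, unique, unknown or untested is made for them only; others in the source may bear on it.

In an ADME assay on NIH3T3 cells (Mus musculus) for cytotoxicity, with a stated time of 72 h (a lower number here means a stronger inhibitor, a higher number a weaker inhibitor), the measured compounds read:
Compound 1 `OC[C@H]1O[C@@H](n2cnc3c(NCc4ccc(F)cc4)ncnc32)[C@H](O)[C@@H]1O`: 44300 nM
Compound 2 `OC[C@H]1O[C@@H](n2cnc3c(NCc4ccc(Br)cc4)ncnc32)[C@H](O)[C@@H]1O`: > 166000 nM (a limit)
Compound 3 `COc1ccccc1CNc1ncnc2c1ncn2[C@@H]1O[C@H](CO)[C@@H](O)[C@H]1O`: 140000 nM

Of the two values that are true numbers, compound 3 holds the higher, with a 3.2-fold higher number from compound 1 to compound 3 (0.50 log units; beyond the scatter). Compound 2 stands at a limit of this assay, so an at least 1.1-fold lower number from compound 2 to compound 3 (0.07 log units; that floor lies within the scatter) gives only a floor.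

Compound 4 `OC[C@H]1O[C@@H](n2cnc3c(NCc4ccc(F)cc4F)ncnc32)[C@H](O)[C@@H]1O` comes next: 2,4-difluorophenyl in place of 2-methoxyphenyl on a saturated chain carbon bound to a nitrogen on an aromatic ring. In words, this is 2,4-difluorophenyl in place of 2-methoxyphenyl on a saturated chain carbon bound to a nitrogen on an aromatic ring. The closest guide is the step that put 2-methoxyphenyl in place of 4-fluorophenyl, a 3.2-fold higher number from compound 1 to compound 3 (0.50 log units; beyond the scatter), read here in reverse. The swap of bromo for fluoro, an at least 3.7-fold higher number from compound 1 to compound 2 (0.57 log units; beyond the scatter), also points to fluorinated compound 1 as the lower reference. A modest fall in this assay is therefore expected, though probably not all the way back to compound 1. The expected change is a 2.2-fold lower number from compound 3 to compound 4 (0.33 log units; beyond the scatter). Compound 4 is estimated at 65000 nM, with an expected range from 25000 nM to 170000 nM.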

Compound 4, half-maximal inhibitory concentration: > 166000 nM
Compound 4 was reported as a limit (the forecaster's own chance of this, stated with the estimate: 15%); middle value at least 2.5-fold (0.40 log units) from the limit.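

In this assay, fluoro in place of hydrogen on an aromatic carbon moves the number beyond the scatter, an at least 3.7-fold higher number from compound 1 to compound 4 (0.57 log units; beyond the scatter), so compound 1 keeps the lowest number of the four, and all three changes to its 4-fluorophenyl group raise it. Against compound 3 there is only a floor, an at least 1.1-fold higher number from compound 3 to compound 4 (0.07 log units; that floor lies within the scatter), so no order can be stated between 2,4-difluorophenyl and 2-methoxyphenyl. The step from compound 2 to compound 4 cannot be read, because both compounds are reported only as limits: the limit of > 166000 nM in this assay, at which 2 of the 4 values shown sit.

On these data alone, how far compound 2 and compound 4 actually lie beyond compound 1 remains unknown. Also open, as far as these compounds go, is how this assay would respond to an amine or a carboxylic acid on the phenyl ring, or to a longer chain in place of the benzyl link.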